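The source may hold more compounds than are shown below. What is called first, only, known or untested is meant among the compounds shown, and "the series" means these compounds.

Measured in a functional assay on HCT-116 cells (Homo sapiens) for cytotoxicity, read by MTT assay, with a stated time of 72 h (on this read-out lower numbers stand for stronger inhibition and higher numbers for weaker inhibition), so far:
- Compound 1 `Nc1cccc(Nc2c(C(=O)NCc3ccc(F)cc3)nc(Br)c3cccnc23)c1` gives > 10000 nM as a limit
- Compound 2 `CN(C)CCCNc1c(C(=O)NCc2ccc(F)cc2)nc(Br)c2cccnc12` gives > 10000 nM as a limit
- Compound 3 `O=C(NCCCNc1c(C(=O)NCc2ccc(F)cc2)nc(Br)c2cccnc12)c1ccccc1` gives > 10000 nM as a limit

Compound 3 gives no number, only a limit, and it shares that position with the other two compounds: the limit of > 10000 nM in this assay, at which 3 of the 3 values shown sit, is all the series shows so far.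

The next change leads to compound 4 `O=C(NCc1ccc(F)cc1)c1nc(Br)c2cccnc2c1NCc1ccccc1` and puts phenyl in place of 2-benzamidoethyl on a saturated chain carbon bound to a nitrogen on an aromatic ring in the counted terms.

Going by the values given here, two measured steps bear on this change, as both alter the same side chain. These are a step that the two limits leave unreadable from compound 1 to compound 2 and a step that the two limits leave unreadable from compound 2 to compound 3 and neither has a size that can be read, so they offer no direction. The expected outcome in this assay is a step that the limit leaves unreadable from compound 3 to compound 4 with no shift beyond the scatter anticipated. For compound 4 the expected value is 12000 nM and a report as a limit is likely. The estimated range for compound 4 runs from 4000 nM to 30000 nM as its expected ends.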

Compound 4, half-maximal inhibitory concentration: > 20000 nM
Compound 4: no number, only a limit; the forecaster's own chance of this, stated with the estimate: 75%; at least 1.6-fold (0.22 log units) between middle value and limit.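

In this assay compound 4 gives > 20000 nM, which is a limit. Going by these compounds alone, no step among compound 1, compound 2, compound 3 and compound 4 can be read. The compounds shown leave open whether any side chain on the shared core gives a numerical value in this assay.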